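Removing the dec-1-en-1-yl chain from an unprotected thioglycoside

This account rests on a few compounds, and the source may have more. Where it says the series, first, only, none or still open, it means among the compounds named here.

The series rests on two cores. Compound 1 `CCCCCCCCCCCC(=O)Nc1nnc(S[C@@H]2O[C@H](COC(C)=O)[C@H](OC(C)=O)[C@H](OC(C)=O)[C@H]2OC(C)=O)s1` and compound 2 `CCCCCCCC/C=C\CCCCCCCCCCCC(=O)Nc1nnc(S[C@@H]2O[C@H](COC(C)=O)[C@H](OC(C)=O)[C@H](OC(C)=O)[C@H]2OC(C)=O)s1` share the acetylated core; compound 3 `CCCCCCCC/C=C\CCCCCCCCCCCC(=O)Nc1nnc(S[C@@H]2O[C@H](CO)[C@H](O)[C@H](O)[C@H]2O)s1` and the unmeasured compound 4 `CCCCCCCCCCCC(=O)Nc1nnc(S[C@@H]2O[C@H](CO)[C@H](O)[C@H](O)[C@H]2O)s1` share the free-hydroxyl core, and the difference between the two cores is not broken down here. In a functional assay on HeLa cells (Homo sapiens) for cytotoxicity, read by MTT assay, with a stated time of 24 h (on this read-out lower numbers stand for stronger inhibition and higher numbers for weaker inhibition), compound 1 gives 51900 nM and compound 2 gives 58500 nM; compound 3 gives 13500 nM, the lowest of the three, with the steps to both others beyond the scatter.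

The change from compound 2 to compound 1, (hydrogen in place of dec-1-en-1-yl on a saturated chain carbon, ten or more bonds along the chain from a carbonyl carbon), gave a 1.1-fold lower number from compound 2 to compound 1 (0.05 log units; within the scatter). The same change is made from compound 3 to compound 4: hydrogen in place of dec-1-en-1-yl on a saturated chain carbon, ten or more bonds along the chain from a carbonyl carbon. Because the earlier step of a 1.1-fold lower number from compound 2 to compound 1 (0.05 log units; within the scatter) stayed within the scatter, the step from compound 3 to compound 4 is expected to be a 1.1-fold lower number from compound 3 to compound 4 (0.05 log units; within the scatter), resting on that single precedent. Compound 4 is therefore estimated at 12000 nM in this assay, between 5000 nM and 30000 nM.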

Compound 4, half-maximal inhibitory concentration: 8700 nM
Estimate against measurement, compound 4: 1.4-fold (0.14 log units) above; the range from low to high includes it.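

In this assay, taking the dec-1-en-1-yl chain off the free-hydroxyl core gave a 1.6-fold lower number from compound 3 to compound 4 (0.19 log units; within the scatter). Set beside the same change on the acetylated core, the two steps do not differ: the same change on two cores in this assay, a 1.1-fold lower number (0.05 log units; within the scatter) from compound 2 to compound 1 and a 1.6-fold lower number (0.19 log units; within the scatter) from compound 3 to compound 4, 1.4-fold (0.14 log units) apart, within the scatter of two such steps. This shows that, on these two cores, the change carries from one to the other without a step beyond the scatter, but two pairs from a single assay do not establish a rule for the wider series or for any other core.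

The compounds shown leave open whether the same holds for a much shorter chain. They also leave open what a chain carrying an amine or a carboxylic acid would give.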